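Swapping the pyridine substituent in a kynurenine 3-monooxygenase inhibitor

A few compounds are considered here, and "the series" means these few. Any claim that something is new, unique, unknown or untested is made for them only; others in the source may bear on it.

Measured compounds:
compound 1, `COCCOc1cc2oc(=O)n(CCC(=O)O)c2cc1Cl`, 31.6 nM
compound 2, `C[C@@H](Oc1cc2oc(=O)n(CCC(=O)O)c2cc1Cl)c1ccc(Cl)cn1`, 3.16 nM
compound 3, `C[C@@H](Oc1cc2onc(CCC(=O)O)c2cc1Cl)c1ccccn1`, 5.01 nM

Of the compounds shown here, three have been tested in an assay for inhibition of kynurenine 3-monooxygenase (Homo sapiens), read by mass spectrometry, with a stated time of 1 h; a higher number here means a weaker inhibitor, a lower number a stronger inhibitor. Compound 2 has the lowest of the three numbers. Compound 3 sits closest to it, and the gap between the two lies within the usual scatter of this assay, so nothing separates them with confidence. Compound 1 stands furthest away, and that gap lies beyond the scatter.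

Compound 4, `Cc1cccc([C@@H](C)Oc2cc3oc(=O)n(CCC(=O)O)c3cc2Cl)n1`, has not yet been measured in this assay. It differs from compound 2 in one place: 6-methylpyridin-2-yl in place of 5-chloropyridin-2-yl on a saturated chain carbon bound to an oxygen on an aromatic ring and a saturated chain carbon. Going by the values given here, no measured pair shows this exact exchange, so there is no step to lean on. The nearest hint is compound 3, whose unsubstituted pyridine on a different core gives a number near that of compound 2. A small step is therefore expected, if any, from compound 2 to compound 4, possibly toward a slightly higher number, as a 1.6-fold higher number from compound 2 to compound 4 (0.20 log units; within the scatter). Compound 4 is estimated at 5 nM, in a range from 1.5 nM to 20 nM.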

Compound 4, half-maximal inhibitory concentration: 5.01 nM
For compound 4 the middle estimate is 1.0-fold (0.00 log units) below the measured one, within the range that was stated.
By their numbers in this assay, from the lowest: compounds 2, 3 and 4 (each within the scatter of the next); then compound 1.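

In this assay, putting 6-methylpyridin-2-yl in place of 5-chloropyridin-2-yl gives a 1.6-fold higher number from compound 2 to compound 4 (0.20 log units; within the scatter), so this change on the saturated chain carbon produces no difference that can be told from the scatter. Going by these compounds alone, this is the first direct reading at this position, since the earlier compounds offered no pair differing only in this group, and it shows that these two substituted pyridines cannot be separated on the shared core. Nothing available bears on why the two groups read alike.

Going by these compounds, a single exchange does not show how much variation this position accepts, so it remains open whether an amine on the pyridine, or a longer chain in place of the methyl, would read the same. Also open, on these data alone, is how the unsubstituted pyridin-2-yl group would read on this same core.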